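The source may hold more compounds than are shown below. What is called first, only, known or untested is meant among the compounds shown, and "the series" means these compounds.

In a functional assay on SF-268 cells (Homo sapiens) for cytotoxicity (on this read-out lower numbers stand for stronger inhibition and higher numbers for weaker inhibition), compound 1 `Oc1cc(O)cc(CCCCCCCCCCCCCCc2cc(O)cc(O)c2)c1` gives 29800 nM and compound 2 `Oc1cc(O)cc(CCCCC/C=C/CCCCCCCc2cc(O)cc(O)c2)c1` gives 30600 nM while compound 3 `Oc1cc2cc(c1)Oc1c(O)cc(cc1O)CCCCCCC/C=C/CCCCC2` gives 33100 nM in the same read-out. These three numbers lie within the scatter of each other, so compound 2 stands level with both other compounds. Compound 4 `COc1cc(O)cc(CCCCCCC/C=C/CCCCCc2cc(O)cc(O)c2)c1` differs from compound 2 by methyl in place of hydrogen on an oxygen on an aromatic ring as methyl in place of hydrogen on an oxygen on an aromatic ring, which reads hydroxy to methoxy. Going by the values given here, no measured pair shows this change alone. Compound 3 at 33100 nM stays level with compound 2 despite its differing structure, so no step beyond the scatter is expected in this assay here. The estimate means a 1.0-fold higher number from compound 2 to compound 4 (0.02 log units; within the scatter) as the expected step. For compound 4 the estimated value is 32000 nM with an expected range from 16000 nM to 65000 nM overall.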

Compound 4, half-maximal inhibitory concentration: 30200 nM
Beside the measured number, compound 4's estimate is 1.1-fold (0.03 log units) above it; the measured number falls inside the stated range.
By their numbers in this assay, from the lowest: compounds 1, 4, 2 and 3 (each within the scatter of the next).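

Methyl in place of hydrogen on this oxygen is the first single-place change that can be read in the series: in this assay, it gives a 1.0-fold lower number from compound 2 to compound 4 (0.01 log units; within the scatter). The free hydroxy at this one position is thus not required to keep the number at the level of compound 2. Nothing available explains this result.

Still open, as far as these compounds go, is whether a larger group on this oxygen, such as benzyl, or an amine or a carboxylic acid in place of the hydroxy, would move the number beyond the scatter. Methylation of further hydroxy groups also remains untested in these compounds.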